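Notes on the step from compound 2 to compound 3

The source may report more compounds than this note shows. Statements on the series, on what has been measured and on what is new or still open speak of the compounds shown alone.

Compound 2 `COc1nc2ccc(Br)cc2cc1C(c1ccccc1)n1cc(-c2ccccc2F)nn1` gives, in an ADME assay on PC-3 cells (Homo sapiens) for cytotoxicity, read by sulforhodamine B assay, with a stated time of 48 h, tested at 10 uM (a lower number here means less inhibition, a higher number more inhibition at the concentration tested (going by the name of the read-out)), a value of 13.4%. For the measured compounds named here, this is the highest of the two numbers measured so far; the nearest is compound 1 `CCCCCCCc1cn(C(c2ccccc2)c2cc3cc(Br)ccc3nc2OC)nn1`, which in this assay gives 4.42%. Going by the values given here, the only step recorded between measured compounds, a number 9 percentage points higher from compound 1 to compound 2 (within the scatter), stays within the scatter, so the two numbers do not separate.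

Compound 3 `COc1nc2ccc(Br)cc2cc1C(c1ccccc1)n1cc(CCCO)nn1` is not yet measured in this assay. It differs from compound 2 in one place: 3-hydroxypropyl in place of 2-fluorophenyl on an aromatic carbon. Among the compounds with values here, the one measured step that bears on this change is a number 9 percentage points higher from compound 1 to compound 2 (within the scatter). That step swaps a group on the same aromatic carbon of the shared core; that exchange of heptyl for 2-fluorophenyl moved the number only within the scatter. Within the data shown here, no measured pair speaks to a 3-hydroxypropyl group at this position, so the expectation rests on that single step alone.

On this basis no step beyond the scatter is expected, a number 5.4 percentage points lower from compound 2 to compound 3 (within the scatter). Compound 3 is estimated at 8% in this assay, with a range from 0% to 22%.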

Compound 3, a percentage reported as inhibition, at one concentration (the size of the read-out at that concentration, not a potency): 14.7%
Beside the measured number, compound 3's estimate is 6.7 percentage points below it, and the stated range covers the measured number.
By their numbers in this assay, from the lowest: compounds 1, 2 and 3 (each within the scatter of the next, the first and the last beyond it).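

In this assay, replacing the aromatic ring of the 2-fluorophenyl group with the open 3-hydroxypropyl chain gives a number 1.3 percentage points higher from compound 2 to compound 3 (within the scatter), so at this position on the five-membered aromatic ring the two compounds do not separate. For the compounds shown here, the comparison of the two chains gives the only step that clears the scatter: a number 10.3 percentage points higher from compound 1 to compound 3 (beyond the scatter), with hydroxy in place of butyl on a saturated chain carbon, three bonds along the chain from an aromatic carbon, and this step is modest. No available evidence accounts for this step or for the lack of separation between the chain and the ring.

The compounds shown leave open whether the step belongs to the hydroxy group itself or to the shorter chain that comes with it, since the two differ together between these compounds. A 3-methoxypropyl group, or a propyl chain carrying an amine or a carboxylic acid in place of the hydroxy, would bear on that question, and a simple propyl group would help to separate the effect of chain length from that of the hydroxy group.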